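Three amides at the assay limit and a fourth to be measured

A few compounds are considered here, and "the series" means these few. Any claim that something is new, unique, unknown or untested is made for them only; others in the source may bear on it.

Compound 1 `COc1cc(N(C)C(=O)c2cccc([N+](=O)[O-])c2)cc(OC)c1OC` carries a methyl on its amide-type nitrogen. In a functional assay on Daoy cells (Homo sapiens) for cytotoxicity, read by MTT assay, with a stated time of 72 h (a lower number here means a stronger inhibitor, a higher number a weaker inhibitor), compound 1 reaches only the limit >= 125000 nM. Compound 2 `COc1cc(NC(=O)c2cccc([N+](=O)[O-])c2)cc(OC)c1OC` is its counterpart with hydrogen in place of methyl on an amide-type nitrogen. In this assay compound 2 likewise stops at the limit >= 125000 nM. The step that the two limits leave unreadable from compound 1 to compound 2 cannot be read, since both ends are limits rather than numbers. Compound 3 `COc1cc(N(C)C(=O)c2ccc([N+](=O)[O-])cc2)cc(OC)c1OC` has the same atoms as compound 1, joined differently; the difference between the two cores is not broken down here. In this assay compound 3 also gives the limit >= 125000 nM. All three values sit at the limit of >= 125000 nM in this assay, at which 3 of the 3 values shown sit.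

Compound 4 `COc1cc(NC(=O)c2ccc([N+](=O)[O-])cc2)cc(OC)c1OC` has not been measured. It differs from compound 3 by hydrogen in place of methyl on an amide-type nitrogen, at a place described in the same words as for compound 1 and compound 2, so it is the same change. Within the data shown here, because every value so far sits at the limit of >= 125000 nM in this assay, at which 3 of the 3 values shown sit, and the one measured instance of this change, a step that the two limits leave unreadable from compound 1 to compound 2, left both ends there, the expected step that the limit leaves unreadable from compound 3 to compound 4 is taken as flat, with no real information on its size. Compound 4 is accordingly expected to return a limit, estimated around 150000 nM in this assay, within 60000 nM to 400000 nM.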

Compound 4, half-maximal inhibitory concentration: 52900 nM
For compound 4 the middle estimate is 2.8-fold (0.45 log units) above the measured one; the whole stated range lies above it.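

In this assay, hydrogen in place of methyl on an amide-type nitrogen gives an at least 2.3-fold lower number from compound 3 to compound 4 (0.37 log units; beyond the scatter), and compound 4 is the only compound shown that returns a number rather than a limit. The one other instance of this change, on the core of compound 1, has limits at both ends and cannot be read, so carrying the step from one core to the other is neither shown nor ruled out. A single readable step on a single core gives no rule for the series, whose values remain largely at the limit: the limit of >= 125000 nM in this assay, at which 3 of the 4 values shown sit.

Still open, from the compounds shown here alone, is whether an ethyl group or a longer chain on the amide nitrogen would give a readable value on either core. Also open, going by these compounds, is how an amine or a carboxylic acid in place of the nitro group would read in this assay.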